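Adding bromo to compound 3: how large a step?

A few compounds are considered here, and "the series" means these few. Any claim that something is new, unique, unknown or untested is made for them only; others in the source may bear on it.

In a functional assay on PC-3 cells (Homo sapiens) for antiproliferative activity, read by sulforhodamine B assay, with a stated time of 48 h (a lower number here means a stronger inhibitor, a higher number a weaker inhibitor), compound 3 `CO/N=C1/C(=O)N(CCCCCCC(=O)NO)c2ccccc21` gives 1670 nM, within the scatter of compound 1 `O=C(CCCCCCN1C(=O)/C(=N\O)c2cc(F)ccc21)NO` at 2730 nM, whereas compound 2 `O=C(CCCCCCN1C(=O)/C(=N\O)c2cc([N+](=O)[O-])ccc21)NO` gives a clearly higher 19700 nM. Compound 4 `CO/N=C1/C(=O)N(CCCCCCC(=O)NO)c2ccc(Br)cc21` has bromo in place of hydrogen on an aromatic carbon of compound 3: bromo in place of hydrogen on an aromatic carbon. For the measured compounds named here, the only measured step that swaps a group on an aromatic carbon is a 7.2-fold higher number from compound 1 to compound 2 (0.86 log units; beyond the scatter), a modest change beyond the scatter, with nitro in place of fluoro. Going by the values given here, no measured step replaces hydrogen with bromo, so that step is only a loose guide. The expected change is a 1.2-fold higher number from compound 3 to compound 4 (0.08 log units; within the scatter), an estimated step probably within the scatter. For compound 4 the estimated value is 2000 nM, with an expected range from 700 nM to 6000 nM.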

Compound 4, half-maximal inhibitory concentration: 8910 nM
Beside the measured number, compound 4's estimate is 4.5-fold (0.65 log units) below it; measured number outside the range, above it.
By their numbers in this assay, from the lowest: compounds 3 and 1 (each within the scatter of the next); then compound 4; then compound 2.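

Replacing hydrogen with bromo on this aromatic carbon gives, in this assay, a 5.3-fold higher number from compound 3 to compound 4 (0.73 log units; beyond the scatter), so a single added atom at this position is enough to shift the number beyond the scatter. This is the first step shown that starts from hydrogen on the ring, and it moves the number upward. Nothing measured here accounts for that rise. From the compounds shown here alone, whether chloro, methyl or an amine on this same carbon would shift the number as far as bromo stays open. So does the effect of bromo on another carbon of that ring.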